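Benzyl exchange on the shared core: compound 3 to compound 4

This account rests on a few compounds, and the source may have more. Where it says the series, first, only, none or still open, it means among the compounds named here.

In a functional assay on CCRF-CEM cells (Homo sapiens) for antiproliferative activity, with a stated time of 72 h (a lower number here means a stronger inhibitor, a higher number a weaker inhibitor), compound 1 `OC[C@H]1O[C@@H](n2cnc3c(NCc4cccc(F)c4)ncnc32)[C@H](O)[C@@H]1O` gives 4000 nM and compound 2 `OC[C@H]1O[C@@H](n2cnc3c(NCc4ccccc4Br)ncnc32)[C@H](O)[C@@H]1O` gives 12300 nM. Compound 3 `Cc1ccc(CNc2ncnc3c2ncn3[C@@H]2O[C@H](CO)[C@@H](O)[C@H]2O)cc1` is reported only as a limit, > 166000 nM. It therefore has no exact position in the series, and steps from it are bounds. Compound 4 `OC[C@H]1O[C@@H](n2cnc3c(NCc4ccc(Cl)c(Cl)c4)ncnc32)[C@H](O)[C@@H]1O` carries 3,4-dichlorophenyl in place of 4-methylphenyl on a saturated chain carbon bound to a nitrogen on an aromatic ring. Among the compounds with values here, no measured compound carries this group. The closest guidance comes from the steps that end at compound 3: an at least 41-fold higher number from compound 1 to compound 3 (1.61 log units; beyond the scatter) and an at least 13-fold higher number from compound 2 to compound 3 (1.13 log units; beyond the scatter), both large. Between the two measured compounds, a 3.1-fold higher number from compound 1 to compound 2 (0.49 log units; beyond the scatter) is modest. Leaving 4-methylphenyl is thus expected to lower the number, though the size is uncertain and another limit remains possible. The expected change is an at least 11-fold lower number from compound 3 to compound 4 (1.04 log units; beyond the scatter), towards a stronger inhibitor. For compound 4 the estimate is 15000 nM, with an expected range of 2500 nM to 100000 nM.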

Compound 4, half-maximal inhibitory concentration: 3800 nM
Beside the measured number, compound 4's estimate is 3.9-fold (0.60 log units) above it, and the stated range covers the measured number.
By their numbers in this assay, from the lowest: compounds 4 and 1 (each within the scatter of the next); then compound 2. At a limit, above all of these: compound 3.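

In this assay, a substituent at 4 on the benzyl ring is not in itself incompatible with a measurable value: 3,4-dichlorophenyl carries one and gives an at least 43-fold lower number from compound 3 to compound 4 (1.64 log units; beyond the scatter), a step that is only a bound. Compound 3 stands as a limit of the assay: the limit of > 166000 nM in this assay, at which 1 of the 4 values shown sits. With 3,4-dichlorophenyl, the position matches 3-fluorophenyl, at a 1.1-fold lower number from compound 1 to compound 4 (0.02 log units; within the scatter), and moves clear of 2-bromophenyl, at a 3.2-fold lower number from compound 2 to compound 4 (0.51 log units; beyond the scatter), so two differently substituted rings now sit level on the shared core.

Going by these compounds, whether one chlorine is enough, as in 4-chlorophenyl or 3-chlorophenyl, remains open, and these compounds cannot separate the contribution of each chlorine in compound 4. Also open, on these data alone, is how the position responds to a ring bearing an amine or a carboxylic acid.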